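From Unsaturated Ester to Saturated Acid

The source may hold more compounds than are shown below. What is called first, only, known or untested is meant among the compounds shown, and "the series" means these compounds.

Values in a functional assay on A549 cells (Homo sapiens) for inhibition, read by sulforhodamine B assay, with a stated time of 72 h; on this read-out higher numbers stand for weaker inhibition of growth and lower numbers for stronger inhibition of growth:
Compound 1 `CCOC(=O)/C=C/c1ccncc1-c1ccc2ccccc2c1`: 5380 nM
Compound 2 `COC(=O)/C=C/c1ccncc1-c1ccc2ccccc2c1`: 760 nM

Compound 2 holds the lower of the two numbers, 760 nM, and so shows the stronger inhibition of growth of the pair. Compound 3 `O=C(O)CCc1ccncc1-c1ccc2ccccc2c1` keeps the shared core but carries 2-carboxyethyl in place of 2-(methoxycarbonyl)ethenyl on an aromatic carbon, (2-carboxyethyl in place of 2-(methoxycarbonyl)ethenyl on an aromatic carbon). Among the compounds with values here, only one measured step bears on this change: a 7.1-fold lower number from compound 1 to compound 2 (0.85 log units; beyond the scatter). That step altered only the far end of the ester, yet it went beyond the scatter. Within the data shown here, the present change replaces the whole group, and no measured compound carries a 2-carboxyethyl group, so its size remains a judgement. A step of similar or larger size is therefore expected in this assay, probably towards a higher number, meaning weaker inhibition of growth. The expected step is a 16-fold higher number from compound 2 to compound 3 (1.20 log units; beyond the scatter). For compound 3 the estimated value is 12000 nM, with an expected range from 2500 nM to 60000 nM.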

Compound 3, concentration for 50% growth inhibition: > 10000 nM
Compound 3: a limit, no number; the forecaster's own chance of this, stated with the estimate: 25%; the middle value does not contradict the limit.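

In this assay compound 3 gives > 10000 nM, a limit of the assay and not a number: the limit of > 10000 nM in this assay, at which 1 of the 3 values shown sits.

Even so, placing 2-carboxyethyl in place of 2-(methoxycarbonyl)ethenyl on this aromatic carbon, opposite the ring nitrogen, gives an at least 13-fold higher number from compound 2 to compound 3 (1.11 log units; beyond the scatter), so the group as a whole matters here, whereas the earlier compounds differed only at the far end of the ester. Set against the ethyl ester, the same kind of change gives an at least 1.8-fold higher number from compound 1 to compound 3 (0.26 log units; that floor lies within the scatter); that floor lies within the scatter, and this comparison does not set the two compounds apart.

The change alters the ester and the chain's double bond together, so the compounds shown leave open whether the loss of growth inhibition goes with the carboxylic acid or with the saturated chain, a question that 2-carboxyethenyl and 2-(methoxycarbonyl)ethyl at this position would separate. Also open, on these data alone, are how an amide or a longer chain would read here, and how far past its limit compound 3 actually lies.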